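This account rests on a few compounds, and the source may have more. Where it says the series, first, only, none or still open, it means among the compounds named here.

Measured compounds:
- Compound 1, `CC1=C(C(=O)NCCCN2CCC(c3ccc(F)cc3)CC2)[C@@H](c2ccc(F)c(F)c2)NC(=O)N1`: 0.39 nM
- Compound 2, `O=C1NC(C(F)(F)F)=C(C(=O)NCCCN2CCC(c3ccc(F)cc3)CC2)[C@@H](c2ccc(F)c(F)c2)N1`: 19 nM

In an assay on CHO cells with Alpha-1A adrenergic receptor (Homo sapiens) as the target (on this read-out higher numbers stand for weaker inhibition and lower numbers for stronger inhibition), compound 1 gives 0.39 nM, and compound 2 gives 19 nM. Going by the values given here, compound 2 therefore stands at the higher of the two numbers, with compound 1 the only neighbour. Among the compounds with values here, the one measured step, a 49-fold higher number from compound 1 to compound 2 (1.69 log units; beyond the scatter), is a trifluoromethyl in place of methyl on a double-bonded ring carbon of the shared core.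

Compound 3, `COCC1=C(C(=O)NCCCN2CCC(c3ccc(F)cc3)CC2)[C@@H](c2ccc(F)c(F)c2)NC(=O)N1`, is not yet measured. It differs from compound 2 by methoxymethyl in place of trifluoromethyl on a double-bonded ring carbon, in words a methoxymethyl in place of trifluoromethyl on a double-bonded ring carbon. Within the data shown here, the only step that bears on this position is the one from compound 1 to compound 2, and it was large, so the substituent at this carbon is seen to matter strongly. Among the measured compounds shown here, no measured step covers methoxymethyl itself. Since compound 2 is expected to lose part of the ground marked by a 49-fold higher number from compound 1 to compound 2 (1.69 log units; beyond the scatter) when the trifluoromethyl leaves, compound 3 is expected to give 3 nM, within 0.6 nM to 15 nM, which means an estimated step of a 6.3-fold lower number from compound 2 to compound 3 (0.80 log units; beyond the scatter) in this assay.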

Compound 3, inhibition constant: 0.24 nM
The estimate for compound 3 lay 13-fold (1.10 log units) above the measured number, and the stated range ends above it.
By their numbers in this assay, from the lowest: compounds 3 and 1 (each within the scatter of the next); then compound 2.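

In this assay, the replacement of trifluoromethyl by methoxymethyl on the double-bonded ring carbon gives a large recovery (a 79-fold lower number from compound 2 to compound 3 (1.90 log units; beyond the scatter)), so the loss seen with trifluoromethyl is not a loss that every replacement for methyl at this carbon brings. The comparison with the methyl compound shows that this carbon also accepts the added methoxy on its saturated chain carbon, since that change stays within the scatter (a 1.6-fold lower number from compound 1 to compound 3 (0.21 log units; within the scatter)), and methyl and methoxymethyl therefore cannot be told apart on this read-out. Nothing shown here gives a measured reason for the gap between trifluoromethyl and the other two groups.

The compounds shown leave open whether the oxygen of methoxymethyl counts for anything at this carbon, a question that an ethyl or propyl group, carrying a plain carbon chain, would help to settle. They also leave open how far this acceptance extends, for instance to a hydroxymethyl, an aminomethyl or a longer ether chain such as ethoxymethyl, and whether a difluoromethyl group would fall with trifluoromethyl or with methyl.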